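Amide aryl swap in the isoxazolone-pyrazine series

The compounds below may be only part of what the source reports. "The series", "measured", "known", "first", "only" and "open" are said of these compounds alone.

Two members of the series have been run in an assay on Jurkat T cells for inhibition of interleukin-2 (Homo sapiens), read by ELISA, with stated times of 10 min and 24 h; on this read-out higher numbers stand for weaker inhibition and lower numbers for stronger inhibition. Compound 1 `Cc1ccc(C2=NOC(C)(C)C2=O)cc1-c1cnc(NC(=O)c2ccccc2F)cn1` carries a 2-fluorophenyl on the amide carbonyl; in this assay compound 1 is recorded as "not active" (no number reported), with no number attached. Compound 2 `Cc1ccc(C2=NOC(C)(C)C2=O)cc1-c1cnc(NC(=O)c2ccccc2Cl)cn1` carries a 2-chlorophenyl at the same position; in this assay compound 2 gives 171 nM, the only numerical result in the set so far, with compound 1 standing beside it without a figure. Among the compounds with values here, no step between measured compounds has been worked out, so the effect of changing the group on the amide carbonyl rests on nothing more than these two readings.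

Compound 3 `Cc1ccc(C2=NOC(C)(C)C2=O)cc1-c1cnc(NC(=O)c2ccncc2)cn1` is the next entry for this assay. It differs from compound 2 by pyridin-4-yl in place of 2-chlorophenyl on a carbonyl carbon. The expectation is a step from compound 2 to compound 3 of a 5.3-fold higher number from compound 2 to compound 3 (0.72 log units; beyond the scatter), towards weaker inhibition, clearly beyond the usual scatter, given that compound 1, which also lacks the 2-chlorophenyl, returned "not active" (no number reported). For compound 3 the estimated value in this assay is 900 nM, with a plausible range from 200 nM to 5000 nM.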

Compound 3, half-maximal inhibitory concentration: "not active" (no number reported)
Compound 3 has no reported number here, so the estimate cannot be set against anything.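

Within the data shown here, with compound 3 recorded as "not active" (no number reported) in this assay, no step from compound 2 can be read, and the same holds for compound 1. No measurement at hand bears on this result. The compounds shown leave open how the readings in this assay would change with other groups on the amide carbonyl.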